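Dropping both hydroxyls from the benzylidene end

The source may report more compounds than this note shows. Statements on the series, on what has been measured and on what is new or still open speak of the compounds shown alone.

Compound 1 `CN(C)CCn1cnnc1-c1cc(Oc2ccc(NC(=O)N/N=C/c3ccc(O)c(O)c3)cc2F)ccn1`: 1930 nM
Compound 2 `Cc1cc(/C=N/NC(=O)Nc2ccc(Oc3ccnc(-c4nncn4CCN(C)C)c3)c(F)c2)cc(C)c1O`: 2010 nM
Compound 3 `Cn1cnnc1-c1cc(Oc2ccc(NC(=O)N/N=C/c3ccccc3)cc2F)ccn1`: 15700 nM

In a functional assay on NCI-H460 cells (Homo sapiens) for cytotoxicity, read by MTT assay, with a stated time of 72 h (on this read-out higher numbers stand for weaker inhibition and lower numbers for stronger inhibition), compound 1 gives 1930 nM, the lowest of the three numbers. Compound 2 sits with it: the step of a 1.0-fold higher number from compound 1 to compound 2 (0.02 log units; within the scatter). Compound 3 is further off, with a clearly higher number than compound 1, although compound 3 differs from compound 1 in two places, not one.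

Compound 4 `CN(C)CCn1cnnc1-c1cc(Oc2ccc(NC(=O)N/N=C/c3ccccc3)cc2F)ccn1` is compound 1 with one change: phenyl in place of 3,4-dihydroxyphenyl on a carbon with a double bond to nitrogen. Among the measured compounds shown here, no measured step follows exactly this change on its own. The step from compound 1 to compound 2 shows that reshaping the substituents on that ring, while keeping one hydroxyl, moves nothing beyond the scatter. Compound 3 carries the same phenyl as compound 4, yet also differs from compound 1 elsewhere in the shared core, so its value only hints that the phenyl may cost potency. On that basis a moderate rise in this assay is expected, roughly a 3.1-fold higher number from compound 1 to compound 4 (0.49 log units; beyond the scatter), and compound 4 is estimated at 6000 nM with a range from 2500 nM to 15000 nM.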

Compound 4, half-maximal inhibitory concentration: 1780 nM
Estimate against measurement, compound 4: 3.4-fold (0.53 log units) above; measured number below the stated range.
By their numbers in this assay, from the lowest: compounds 4, 1 and 2 (each within the scatter of the next); then compound 3.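

On the carbon with a double bond to nitrogen, the ring can lose both of its hydroxyls without any change beyond the scatter in this assay: the record shows a 1.1-fold lower number from compound 1 to compound 4 (0.04 log units; within the scatter) and also a 1.1-fold lower number from compound 2 to compound 4 (0.05 log units; within the scatter) for the loss of the hydroxyl and the two methyl groups of the 4-hydroxy-3,5-dimethylphenyl. Compounds 1, 2 and 4 therefore show that, with the rest of the structure held the same, this assay does not separate the plain phenyl from either substituted ring, so neither hydroxyl pattern is needed to keep this level of activity. The clear difference lies at the other end of the molecule, since an 8.8-fold lower number from compound 3 to compound 4 (0.95 log units; beyond the scatter) comes with (dimethylamino)methyl in place of hydrogen on a saturated chain carbon bound to an aromatic nitrogen, which means that the high number of compound 3 says nothing against the phenyl.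

Still open, from the compounds shown here alone, is whether an amine or a carboxylic acid on that phenyl would leave the number unmoved as the hydroxyls did, and how a longer chain would compare at the other site. Nothing measured here explains why one site responds and the other does not.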